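Methoxy to hydroxy on compound 2

The source may report more compounds than this note shows. Statements on the series, on what has been measured and on what is new or still open speak of the compounds shown alone.

In a physicochemical assay, read by spectrophotometry, with a stated time of 15 min (on this read-out higher numbers stand for weaker inhibition and lower numbers for stronger inhibition), two compounds have readings so far. Compound 1 (`O=C(CCc1nc2ccccc2c(=O)[nH]1)N/N=C/c1ccc(O)cc1`) reads 300000000 nM in this test, and compound 2 (`COc1cc(/C=N/NC(=O)CCCc2nc3ccccc3c(=O)[nH]2)cc(OC)c1OC`) reads 85000000 nM in the same test. Compound 2 therefore holds the lower of the two numbers, and the gap between them lies beyond the usual scatter. The two structures differ in more than one place, so that gap isolates no single change.

Compound 3 (`COc1cc(/C=N/NC(=O)CCCc2nc3ccccc3c(=O)[nH]2)cc(OC)c1O`) is compound 2 with one alteration: hydrogen in place of methyl on an oxygen on an aromatic ring, which turns methoxy into hydroxy. Among the measured compounds shown here, no measured pair shows this change alone, so its size can only be judged. Compound 1 also carries a hydroxy group on an aromatic ring and reads 300000000 nM as the higher number, which keeps the expected range wide. In this assay a moderate move toward stronger inhibition is still expected, estimated as a 2.8-fold lower number from compound 2 to compound 3 (0.45 log units; beyond the scatter) for this step. Compound 3 is estimated at 30000000 nM (expected range 5000000 nM to 120000000 nM).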

Compound 3, half-maximal inhibitory concentration: 225000000 nM
Compound 3: the middle estimate sits 7.5-fold (0.88 log units) below what was measured, outside the stated range (above it).
By their numbers in this assay, from the lowest: compound 2; then compounds 3 and 1 (each within the scatter of the next).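

In this assay the change from methoxy to hydroxy on this aromatic ring moves toward weaker inhibition, with a 2.6-fold higher number from compound 2 to compound 3 (0.42 log units; beyond the scatter) in a modest step that lies beyond the scatter. Among the compounds shown here, this is the first reading of the change on its own: compound 1 and compound 2 differ in more than one place, so the hydroxy group on the aromatic ring of compound 1 could not be read separately from its other differences. Here only a methyl leaves, replaced by a hydrogen on the oxygen, and the direction at this position is therefore clear for this one pair, though no measurement shown accounts for it.

From the compounds shown here alone, whether a different group on the same oxygen, such as an ethyl or a longer chain, would read closer to compound 2 or to compound 3 remains open, as does the effect of an amine in place of the hydroxy on the aromatic ring. Going by these compounds, it also remains open whether the same change at the other methoxy groups of compound 2 would give a step of similar direction and size.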